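The source may hold more compounds than are shown below. What is called first, only, known or untested is meant among the compounds shown, and "the series" means these compounds.

Compound 1 `Cn1c(/C=C2\SC(=O)N(CC(=O)N3CCOCC3)C2=O)nc2ccccc21`: in a functional assay on PC-3 cells (Homo sapiens) for inhibition, read by MTT assay, with a stated time of 48 h (on this read-out lower numbers stand for stronger inhibition and higher numbers for weaker inhibition), compound 1 gives > 50000 nM, which is a limit of the assay and not a number.
Compound 2 `Cn1c(/C=C2\SC(=O)N(CC(=O)N3CCCC3)C2=O)nc2ccccc21`: in this assay compound 2 gives > 50000 nM, again a limit.
Compound 3 `CCn1c(/C=C2\SC(=O)N(CC(=O)N3CC(C)OC(C)C3)C2=O)nc2ccccc21`: in this assay compound 3 gives > 50000 nM, also a limit.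

Compound 3 thus stands at the limit shared by every measured compound, as summed up by the limit of > 50000 nM in this assay, at which 3 of the 3 values shown sit. Compound 4 `CC1CN(C(=O)CN2C(=O)S/C(=C\c3nc4ccccc4n3C)C2=O)CC(C)O1` differs from compound 3 by hydrogen in place of methyl on a saturated chain carbon bound to an aromatic nitrogen. Among the measured compounds shown here, only one measured step exists, and it does not touch this position: the step that the two limits leave unreadable from compound 1 to compound 2 changes the amide-bound ring, and since both ends are limits its size cannot be read. No measured step therefore bears directly on the change from compound 3 to compound 4, and nothing among the shown values suggests a move away from the limit. The step that the limit leaves unreadable from compound 3 to compound 4 is expected to be none beyond the scatter, with compound 4 most likely reported as a limit as well. Compound 4 is estimated at 60000 nM in this assay, within 20000 nM to 200000 nM.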

Compound 4, half-maximal inhibitory concentration: > 50000 nM
Compound 4 ended at the assay's limit; the forecaster's own chance of this, stated with the estimate: 85%; the middle value is on the limit's open side.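

Compound 4 shares its limit with compound 1, compound 2 and compound 3, so none of the steps from those three compounds to compound 4 can be read. The compounds shown leave open what any of them would give as an actual number, and which change, if any, would bring a readable value, as all remain at one limit: the limit of > 50000 nM in this assay, at which 4 of the 4 values shown sit.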